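The source may hold more compounds than are shown below. What is called first, only, known or untested is meant among the compounds shown, and "the series" means these compounds.

Measured in an ADME assay on MCF-10A cells (Homo sapiens) for inhibition, with a stated time of 48 h (a higher number here means a weaker inhibitor, a lower number a stronger inhibitor), each value a limit and not a number:

Compound 1 `O=C(Nc1ccc(I)cc1)N1CCC[C@H]1c1nc(-c2ccccc2)no1`: > 50000 nM
Compound 2 `O=C(Nc1ccc(C(F)(F)F)cc1)N1CCC[C@H]1c1nc(-c2ccccc2)no1`: > 50000 nM
Compound 3 `O=C(Nc1ccc(Cl)cc1)N1CCC[C@H]1c1nc(-c2ccccc2Cl)no1`: > 50000 nM

Compound 3 offers no exact number, only the limit > 50000 nM. The wider picture is the same: the limit of > 50000 nM in this assay, at which 3 of the 3 values shown sit.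

Compound 4 `Cc1ccc(-c2noc([C@@H]3CCCN3C(=O)Nc3ccc(Cl)cc3)n2)cc1` carries 4-methylphenyl in place of 2-chlorophenyl, on an aromatic carbon of a five-membered aromatic ring with 2 nitrogen and 1 oxygen: 4-methylphenyl in place of 2-chlorophenyl on an aromatic carbon.

Going by the values given here, only one measured step exists, a step that the two limits leave unreadable from compound 1 to compound 2. It swaps trifluoromethyl for iodo, which is a different change at a different place, and its size cannot be read. Nothing measured therefore bears directly on this swap, and no direction can be drawn from the data. In this assay, no step beyond the usual scatter is expected, so compound 4 should most likely stay at the same limit.

The expected step is a number no higher from compound 3 to compound 4 (the limit leaves the size open).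

For compound 4 the estimate is 50000 nM, with an expected range from 25000 nM to 100000 nM.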

Compound 4, half-maximal inhibitory concentration: > 50000 nM
Compound 4: no number, only a limit; the forecaster's own chance of this, stated with the estimate: 80%; the middle value sits exactly at the limit.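

Compound 3 and compound 4 each give only a limit, not a number, so the step from 2-chlorophenyl to 4-methylphenyl cannot be read. The compounds shown leave open whether any change to this series gives a readable value in this assay, as all share one result: the limit of > 50000 nM in this assay, at which 4 of the 4 values shown sit.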